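The source may hold more compounds than are shown below. What is called first, only, known or untested is meant among the compounds shown, and "the series" means these compounds.

Measured in an assay for binding affinity to dual specificity mitogen-activated protein kinase kinase 4 (Homo sapiens), read by KINOMEscan, tested at 100 nM; on this read-out higher numbers stand for a weaker effect at the one concentration tested and lower numbers for a stronger effect:
compound 1 `CCCS(=O)(=O)Nc1ccc(F)c(C(=O)c2n[nH]c3ncc(-c4cccc(Cl)c4)cc23)c1F`: 40%
compound 2 `CCCS(=O)(=O)Nc1ccc(F)c(C(=O)c2n[nH]c3ncc(-c4ccc(S(=O)(=O)NC)cc4)cc23)c1F`: 1.2%
compound 3 `CCCS(=O)(=O)Nc1ccc(F)c(C(=O)c2n[nH]c3ncc(-c4ccc(S(=O)(=O)NC(C)=O)cc4)cc23)c1F`: 0.35%

Compound 3 stands lowest of the three numbers in this assay; compound 2 is its nearest neighbour and the two lie within the scatter of each other, while compound 1 sits well apart. Compound 4 `CCCS(=O)(=O)Nc1ccc(F)c(C(=O)c2n[nH]c3ncc(-c4ccc(-c5nnn[nH]5)cc4)cc23)c1F` is not yet measured. It differs from compound 3 in one place: 1H-tetrazol-5-yl in place of acetylsulfamoyl on an aromatic carbon. For the measured compounds named here, two measured steps bear on this. The change a number 38.8 percentage points lower from compound 1 to compound 2 (beyond the scatter) shows that replacing 3-chlorophenyl by 4-(methylsulfamoyl)phenyl moves the read-out strongly downward. The change a number 0.9 percentage points lower from compound 2 to compound 3 (within the scatter) shows that altering the group on the sulfonamide nitrogen leaves the number essentially where it was. Going by the values given here, the present change goes further, exchanging the whole acetylsulfamoyl for 1H-tetrazol-5-yl, so somewhat more movement than in the second step is possible, but no measured step indicates a return toward the level of compound 1. Compound 4 is therefore expected to give about 2%, range 0.2% to 15%, in this assay. The step expected is a number 1.7 percentage points higher from compound 3 to compound 4 (within the scatter), most likely within the scatter.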

Compound 4, a percentage reported as activity, at one concentration (the size of the read-out at that concentration, not a potency): 0.15%
The estimate for compound 4 lay 1.9 percentage points above the measured number; the whole stated range lies above it.
By their numbers in this assay, from the lowest: compounds 4, 3 and 2 (each within the scatter of the next); then compound 1.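

In this assay, the site on the six-membered aromatic ring of carbon only, para to a large group, accepts a five-membered aromatic ring with 4 hetero atoms as readily as either sulfonamide group: 1H-tetrazol-5-yl replacing acetylsulfamoyl gives one step (a number 0.2 percentage points lower from compound 3 to compound 4 (within the scatter)), and replacing methylsulfamoyl gives another (a number 1.1 percentage points lower from compound 2 to compound 4 (within the scatter)). A sulfonamide is therefore not needed for the low read-out, and the large gap to the 3-chlorophenyl compound holds with a group containing no sulfur (a number 39.9 percentage points lower from compound 1 to compound 4 (beyond the scatter)). Nothing measured here accounts for this likeness among the groups.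

Compounds 2, 3 and 4 lie within the scatter of each other and cannot be ranked as having a stronger or weaker effect at this single concentration. Still open, going by these compounds, is how a carboxylic acid or a primary amide at this site would read, and whether 4-chlorophenyl would stay near compound 1.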